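The compounds below may be only part of what the source reports. "The series", "measured", "known", "first", "only" and "open" are said of these compounds alone.

Values in a functional assay on MDA-MB-231 cells (Homo sapiens) for antiproliferative activity, read by MTT assay, with a stated time of 24 h; on this read-out higher numbers stand for an effect only at larger amounts of compound and lower numbers for an effect already at smaller amounts:
- compound 1 `CSc1ccc(/C(=N\O)c2cccc3ccccc23)cc1`: 20000 nM
- compound 2 `CCN(CC)C(=O)CO/N=C(\c1ccc(SC)cc1)c1cccc2ccccc12`: 30000 nM
- compound 3 `CCCCC(CC)CNCCCO/N=C(\c1ccc(OC)cc1)c1cccc2ccccc12`: > 50000 nM (a limit, not a number)

Compound 2, at 30000 nM, lies within the scatter of compound 1, its nearest neighbour on the numbers. Among the measured compounds shown here, with compound 3 reported only as a limit, these are the only two numeric values, so the scale is poorly anchored.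

The next compound to consider is compound 4 `CSc1ccc(/C(=N\OCCCCN2CCCCC2)c2cccc3ccccc23)cc1`. The change from compound 2 is 3-(piperidin-1-yl)propyl in place of diethylcarbamoyl on a saturated chain carbon bound to an oxygen on an unsaturated carbon. In words, 3-(piperidin-1-yl)propyl takes the place of diethylcarbamoyl on a saturated chain carbon bound to an oxygen on an unsaturated carbon.

For the measured compounds named here, only one measured step bears directly on this position: a 1.5-fold higher number from compound 1 to compound 2 (0.18 log units; within the scatter). That step is small, and it gives no measured size for replacing one substituent on this chain with another. Also relevant is the limit of > 50000 nM in this assay, at which 1 of the 3 values shown sits, so a result for compound 4 could arrive as a limit rather than a number.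

No shift beyond the scatter is therefore expected in this assay, in either direction. The expected change is a 1.2-fold lower number from compound 2 to compound 4 (0.08 log units; within the scatter). For compound 4 the estimated value is 25000 nM, with an expected range of 8000 nM to 50000 nM.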

Compound 4, half-maximal effective concentration: 18000 nM
For compound 4 the middle estimate is 1.4-fold (0.14 log units) above the measured one; the measured number falls inside the stated range.
By their numbers in this assay, from the lowest: compounds 4, 1 and 2 (each within the scatter of the next). At a limit, above all of these: compound 3.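

In this assay, among the compounds shown here, 3-(piperidin-1-yl)propyl in place of diethylcarbamoyl, on a saturated chain carbon bound to an oxygen on an unsaturated carbon, gives a 1.7-fold lower number from compound 2 to compound 4 (0.22 log units; within the scatter), the first measured exchange of one substituent for another at this position. Set against hydrogen on that oxygen, 4-(piperidin-1-yl)butyl gives a 1.1-fold lower number from compound 1 to compound 4 (0.05 log units; within the scatter), and (diethylcarbamoyl)methyl gives a 1.5-fold higher number from compound 1 to compound 2 (0.18 log units; within the scatter), so neither chain, with or without the six-membered non-aromatic ring, separates from the unsubstituted compound in this assay. Compound 4 also returns a number and not a limit, which shows that a chain ending in piperidine can be read on this scale, although the readable values cannot be put in any order.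

Compound 3 remains a limit and not a number: the limit of > 50000 nM in this assay, at which 1 of the 4 values shown sits. From the compounds shown here alone, it remains open whether a much shorter chain, a morpholine ring in place of piperidine, or a carboxylic acid at the end of the chain would move the number beyond the scatter at this position.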